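Changing the group on sulfur: compound 2 to compound 3

This account rests on a few compounds, and the source may have more. Where it says the series, first, only, none or still open, it means among the compounds named here.

Compound 1 `Nc1ccccc1NC(=O)/C=C/c1ccc(CSc2cccc3ccccc23)cc1`: 830 nM
Compound 2 `Nc1ccccc1NC(=O)/C=C/c1ccc(CSCCc2ccccc2)cc1`: 1150 nM
Compound 3 `CC(C)(C)c1ccc(SCc2ccc(/C=C/C(=O)Nc3ccccc3N)cc2)cc1`: not yet measured

In a functional assay on A549 cells (Homo sapiens) for antiproliferative activity, read by CCK-8 assay, with a stated time of 72 h (on this read-out higher numbers stand for weaker inhibition and lower numbers for stronger inhibition), compound 2 gives 1150 nM, a value within the scatter of compound 1. Compound 3 carries 4-(tert-butyl)phenyl in place of phenethyl on a sulfur. Within the data shown here, only one measured step bears on this change, an earlier exchange at the same sulfur, phenethyl in place of naphthalen-1-yl. That step is a 1.4-fold higher number from compound 1 to compound 2 (0.14 log units; within the scatter), so it stays within the scatter. Among the measured compounds shown here, a single step is thin evidence, and no measured compound yet pairs the entering group with the shared core. On that basis, no shift beyond the scatter is expected in this assay, in either direction. The expected step is a 1.2-fold lower number from compound 2 to compound 3 (0.08 log units; within the scatter). For compound 3 the estimated value is 950 nM, with an expected range from 350 nM to 2500 nM.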

Compound 3, half-maximal inhibitory concentration: 640 nM
Compound 3: the middle estimate sits 1.5-fold (0.17 log units) above what was measured, within the range that was stated.
By their numbers in this assay, from the lowest: compounds 3, 1 and 2 (each within the scatter of the next).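

In this assay, a third group on this sulfur again leaves the number within the scatter: the data give a 1.8-fold lower number from compound 2 to compound 3 (0.25 log units; within the scatter) and also a 1.3-fold lower number from compound 1 to compound 3 (0.11 log units; within the scatter) for the exchange of naphthalen-1-yl. Where a single step stood before, three groups can now be compared at this place, and 4-(tert-butyl)phenyl, naphthalen-1-yl and phenethyl give numbers that all lie within the scatter of the next, so this assay does not separate them. No measurement shown here offers an explanation for this lack of separation.

The groups compared so far at this sulfur are all built on aromatic rings of carbon. From the compounds shown here alone, whether a carboxylic acid, an amine-bearing chain or a small methyl group at the same place would move the number beyond the scatter remains open.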